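The compounds below may be only part of what the source reports. "The series", "measured", "known", "first", "only" and "open" are said of these compounds alone.

Going by the values given here, compound 1 `COc1cc(Nc2nc3ccccc3nc2S(=O)(=O)c2ccc(C)cc2)cc(OC)c1` is one of three compounds measured in a functional assay on PC-3 cells (Homo sapiens) for cytotoxicity, read by MTT assay, with a stated time of 72 h (a higher number here means a weaker inhibitor, a lower number a stronger inhibitor), where compound 1 gives 2940 nM as its reading. Among those three numbers compound 1 holds the second highest place. Compound 2 `Cc1ccc(S(=O)(=O)c2nc3ccccc3nc2Nc2cccc(O)c2)cc1` gives 1690 nM, and the move from compound 1 to compound 2 is a 1.7-fold lower number from compound 1 to compound 2 (0.24 log units; within the scatter) in size. Compound 3 `Cc1ccc(S(=O)(=O)c2nc3ccccc3nc2Nc2ccc(Cl)cc2)cc1` gives 9660 nM, a step of a 3.3-fold higher number from compound 1 to compound 3 (0.52 log units; beyond the scatter) from compound 1, while from compound 2 the step is a 5.7-fold higher number from compound 2 to compound 3 (0.76 log units; beyond the scatter) in size. All three measured compounds share the same core and differ only in the ring attached to the nitrogen.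

Compound 4 `COc1cc(Nc2nc3ccccc3nc2S(=O)(=O)c2ccc(Br)cc2)cc(OC)c1` differs from compound 1 elsewhere: bromo in place of methyl on an aromatic carbon. Among the compounds with values here, none of the measured steps touches this part of the molecule; each of them swaps the ring on the nitrogen, and the ring carrying the methyl is the same in all three measured compounds. Within the data shown here, no measured step therefore speaks to this change, and there is no ground to expect a shift beyond the scatter in either direction. The estimate for compound 4 thus amounts to a step of a 1.0-fold higher number from compound 1 to compound 4 (0.01 log units; within the scatter) from compound 1. Compound 4 is expected to give 3000 nM in this assay, with a range from 1200 nM to 7500 nM.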

Compound 4, half-maximal inhibitory concentration: 18200 nM
Compound 4: middle estimate off by 6.1-fold (0.78 log units), on the low side; measured number above the stated range.
By their numbers in this assay, from the lowest: compounds 2 and 1 (each within the scatter of the next); then compounds 3 and 4 (each within the scatter of the next).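

The ring on the sulfonyl group is not a silent part of the molecule: in this assay, the change from (4-methylphenyl)sulfonyl to (4-bromophenyl)sulfonyl gives a 6.2-fold higher number from compound 1 to compound 4 (0.79 log units; beyond the scatter), which means a weaker inhibitor after one group on an aromatic carbon is exchanged. Going by these compounds alone, all the earlier steps changed only the ring on the nitrogen, such as a 3.3-fold higher number from compound 1 to compound 3 (0.52 log units; beyond the scatter), so this is the first sign that the other end of the molecule can also move the reading beyond the scatter. Methyl and bromo each count one heavy atom and neither carries a hydrogen-bond donor or acceptor, so these counts do not separate them, and nothing available explains the shift.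

Going by these compounds, what a fluoro, a methoxy or an amine would give at this same place remains open, so a single step cannot show whether bromo is unusual here or whether the methyl is simply hard to replace. Also open, on these data alone, is whether bromo in place of methyl would give a similar step with 3-hydroxyphenyl or 4-chlorophenyl on the nitrogen.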